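This account rests on a few compounds, and the source may have more. Where it says the series, first, only, none or still open, it means among the compounds named here.

Compound 1 is `CCC1(Cc2ccccc2)OS(=O)(=O)C=C1OCc1ccc([N+](=O)[O-])cc1`. In an ADME assay on HEL cells (Homo sapiens) for cytotoxicity, with a stated time of 3 days (on this read-out lower numbers stand for higher toxicity in this test and higher numbers for lower toxicity in this test), compound 1 gives >= 80000 nM, which is a limit of the test rather than a measured number, so compound 1 stands among values that are all limits. Compound 2, `CCC1(Cc2ccccc2)OS(=O)(=O)C=C1OCc1ccc(Cl)cc1`, gives >= 50000 nM, again a limit. Compound 3, `CCC1(Cc2ccccc2)OS(=O)(=O)C=C1OC`, gives > 400000 nM, likewise a limit. The steps among them, a step that the two limits leave unreadable from compound 1 to compound 2, a step that the two limits leave unreadable from compound 1 to compound 3 and a step that the two limits leave unreadable from compound 2 to compound 3, therefore cannot be read in size. Compound 4 is `CCC1(Cc2ccccc2)OS(=O)(=O)C=C1OCCc1ccccc1`; it differs from compound 1 in one place: benzyl in place of 4-nitrophenyl on a saturated chain carbon bound to an oxygen on an unsaturated carbon. Among the measured compounds shown here, the steps that bear on this change are the three just named, and each is unreadable, so the size of the step in this assay cannot be anticipated from them; the expectation is simply another limit, with no step beyond the scatter, which is what a step that the limit leaves unreadable from compound 1 to compound 4 expresses. Compound 4 is therefore estimated at 100000 nM, within the range 40000 nM to 400000 nM.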

Compound 4, minimum cytotoxic concentration: >= 20000 nM
Compound 4: only a limit was reported; the forecaster's own chance of this, stated with the estimate: 85%; the middle value lies beyond the limit too.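

In this assay compound 4 gives >= 20000 nM, which is a limit. Compound 1, compound 2 and compound 3 also stand only as limits, and no step among these four compounds can be read. The compounds shown leave open whether exchanging these groups changes cytotoxicity at all.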